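The source may report more compounds than this note shows. Statements on the series, on what has been measured and on what is new or still open speak of the compounds shown alone.

Values in an ADME assay on a cell-free system (plasma, Rattus norvegicus) for protein binding, for the series so far:

compound 1 `COc1ccc(F)cc1-c1ccnc2[nH]c(C3=CCC(C(=O)O)CC3)cc12` gives 99.6% in this read-out
compound 2 `COc1ccc(F)cc1-c1ccnc2[nH]c(C3=CCN([C@H]4CC[C@H](C(=O)O)CC4)CC3)cc12` gives 91% in this read-out
compound 3 `COc1ccc(F)cc1-c1c(F)cnc2[nH]c(C3=CCN([C@H]4CC[C@H](C(=O)O)CC4)CC3)cc12` gives 89.4% in this read-out

Compound 3 at 89.4% sits within the scatter of compound 2 at 91% and both stand well apart from compound 1 at 99.6% on the unbound fraction.

The next compound is compound 4 `COc1ccc(F)cc1-c1c(F)cnc2[nH]c(C3=CCN([C@H]4CC[C@H](CC(=O)O)CC4)CC3)cc12` and the change leading to it is carboxymethyl in place of carboxy on a saturated ring carbon. Within the data shown here, the one measured step confined to a single place is a 1.2-fold higher unbound fraction from compound 2 to compound 3 (0.07 log units; within the scatter) for fluoro in place of hydrogen on an aromatic carbon. Among the measured compounds shown here, that step is a change of another kind, and no measured step touches the carboxy group, so the size of this change has no direct precedent. Compound 1 differs from compound 2 in more than one place and gives no clean guide. With so little to go on, no shift beyond the scatter is expected in this assay and no direction is firmly expected. The estimate amounts to a 1.2-fold lower unbound fraction from compound 3 to compound 4 (0.07 log units; within the scatter) as the expected step. For compound 4 the estimated value is 91% within an expected range of 84% to 96% in this read-out.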

Compound 4, plasma protein binding: 91.8%
The estimate for compound 4 lay 1.1-fold (0.04 log units) (unbound fraction) above the measured number; the range from low to high includes it.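

In this assay, the step from 4-carboxycyclohexyl to 4-(carboxymethyl)cyclohexyl is the first single-place change shown on the carboxy-bearing end of the series, and it gives a 1.3-fold lower unbound fraction from compound 3 to compound 4 (0.11 log units; within the scatter). At this saturated ring carbon, three ring bonds from the ring atom that bears a large group, carboxy and carboxymethyl therefore cannot be told apart in this read-out, and the second single-place step, a 1.2-fold higher unbound fraction from compound 2 to compound 3 (0.07 log units; within the scatter), on an aromatic carbon, is also within the scatter. No supporting data bear on why this change leaves the read-out within the scatter.

On these data alone, whether a longer chain such as carboxyethyl, or an amine in place of the carboxylic acid at this ring carbon, would give a step beyond the scatter remains open. Compound 1, at 99.6%, differs from compound 2 in more than one place, so the shown compounds do not settle which of those differences goes with its value.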